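The source may hold more compounds than are shown below. What is called first, only, known or untested is meant among the compounds shown, and "the series" means these compounds.

Measured in a functional assay on MGC-803 cells (Homo sapiens) for inhibition, read by MTT assay, with a stated time of 72 h; a higher number here means a weaker inhibitor, a lower number a stronger inhibitor:
- compound 1 `C#CCSc1nc2nc(C)cc(Nc3cc(-c4ccccc4)[nH]n3)n2n1` gives 13400 nM
- compound 2 `Cc1cc(Nc2cc(-c3ccccc3)[nH]n2)n2nc(SCc3nc4ccccc4[nH]3)nc2n1` gives 1790 nM

Of these two numbers, compound 2 holds the lower, which makes it the stronger inhibitor in this assay. Its nearest neighbour is compound 1, and the measured step is a 7.5-fold lower number from compound 1 to compound 2 (0.87 log units; beyond the scatter), a modest change that lies beyond the scatter.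

The next compound is compound 3 `CCCSc1nc2nc(C)cc(Nc3cc(-c4ccccc4)[nH]n3)n2n1`, which has not yet been measured. It differs from compound 2 as follows: ethyl in place of 1H-benzimidazol-2-yl on a saturated chain carbon bound to a sulfur. Among the compounds with values here, only one measured step bears on this change. That step brought 1H-benzimidazol-2-yl onto the same saturated chain carbon bound to a sulfur, and the new change removes that group again. Ethyl now enters where compound 1 carried ethynyl, and no measurement yet compares those two groups. The step of a 7.5-fold lower number from compound 1 to compound 2 (0.87 log units; beyond the scatter) is therefore expected to be largely reversed, with a rise of similar size and a number close to that of compound 1 at 13400 nM.

The estimated change is a 6.1-fold higher number from compound 2 to compound 3 (0.79 log units; beyond the scatter).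

Compound 3 is expected at 11000 nM, within an estimated range of 4500 nM to 27000 nM.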

Compound 3, half-maximal inhibitory concentration: 12600 nM
For compound 3 the middle estimate is 1.1-fold (0.06 log units) below the measured one; the range from low to high includes it.
By their numbers in this assay, from the lowest: compound 2; then compounds 3 and 1 (each within the scatter of the next).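

In this assay, the new result gives the change on the saturated chain carbon bound to a sulfur a second reading: with ethyl in place of 1H-benzimidazol-2-yl there is a 7.0-fold higher number from compound 2 to compound 3 (0.85 log units; beyond the scatter), so the advantage of compound 2 now stands against two small groups rather than one. Ethyl and ethynyl, which no earlier measurement compared, cannot be told apart here, with a 1.1-fold lower number from compound 1 to compound 3 (0.03 log units; within the scatter), so among these three compounds only 1H-benzimidazol-2-yl sets its compound apart. Nothing measured on these compounds accounts for that difference.

The compounds shown leave open which part of the 1H-benzimidazol-2-yl group matters, since both of its rings and its hydrogen-bond donor and acceptor leave together, and a phenyl or an imidazol-2-yl group in the same place would be needed to separate them. On these data alone, whether a longer chain, an amine or a carboxylic acid there would give a number close to that of compound 3 or close to that of compound 2 also remains open.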